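This account rests on a few compounds, and the source may have more. Where it says the series, first, only, none or still open, it means among the compounds named here.

Measured so far, in a physicochemical assay for solubility, measured as kinetic solubility, at pH 2; on this read-out lower numbers stand for lower solubility and higher numbers for higher solubility:
- compound 1 `CC(C)C(CC1C(=O)NC(=O)N1C)c1ccc(-c2ccc3cccc(F)c3c2)[nH]c1=O`: 26600 nM
- compound 2 `CC(C)[C@@H](c1ccc(-c2ccc3cccc(F)c3c2)[nH]c1=O)[C@@H]1OC(=O)NC1=O`: 6900 nM

Compound 2 stands at 6900 nM, the lower of the two numbers, and its gap to compound 1 lies beyond the scatter.

Compound 3 `CC(C)[C@H](C[C@H]1OC(=O)NC1=O)c1ccc(-c2ccc3cccc(F)c3c2)[nH]c1=O` differs from compound 2 in one place: (2,4-dioxo-1,3-oxazolidin-5-yl)methyl in place of 2,4-dioxo-1,3-oxazolidin-5-yl on a saturated chain carbon bound to an aromatic carbon and a saturated chain carbon. A (2,4-dioxo-1,3-oxazolidin-5-yl)methyl stands in place of 2,4-dioxo-1,3-oxazolidin-5-yl on a saturated chain carbon bound to an aromatic carbon and a saturated chain carbon.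

Going by the values given here, no measured pair shows this change alone, so the expectation in this assay is weakly founded. It rests only on compound 2 at 6900 nM and compound 1 at 26600 nM. A slight rise is expected, probably none beyond the scatter, and the expected step is a 1.3-fold higher number from compound 2 to compound 3 (0.12 log units; within the scatter). For compound 3 the estimate is 9000 nM, with an expected range from 3000 nM to 27000 nM.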

Compound 3, solubility: 24400 nM
Beside the measured number, compound 3's estimate is 2.7-fold (0.43 log units) below it; measured number inside the range.
By their numbers in this assay, from the lowest: compound 2; then compounds 3 and 1 (each within the scatter of the next).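

In this assay the saturated chain carbon bound to an aromatic carbon and a saturated chain carbon is now shown to be a place where the read-out moves: (2,4-dioxo-1,3-oxazolidin-5-yl)methyl in place of 2,4-dioxo-1,3-oxazolidin-5-yl gives a 3.5-fold higher number from compound 2 to compound 3 (0.55 log units; beyond the scatter) on an otherwise unchanged core. Going by these compounds alone, this is the first comparison that differs in one place, and the step, though modest, lies beyond the scatter. No measurement at hand accounts for the step.

Still open, on these data alone, is whether a longer chain between this carbon and the 2,4-dioxo-1,3-oxazolidin-5-yl ring would extend the step or reverse it. Also open, as far as these compounds go, is whether a carboxylic acid or an amine at this place would give a number like that of either ring-bearing group.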